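Compound 3 and the exchange on the chain carbon

The compounds below may be only part of what the source reports. "The series", "measured", "known", "first", "only" and "open" are said of these compounds alone.

Values in a functional assay on MCF7 cells (Homo sapiens) for inhibition, read by MTT assay, with a stated time of 3 days; on this read-out higher numbers stand for weaker inhibition and lower numbers for stronger inhibition:
Compound 1 `CCOC(=O)CN(C)CC(=O)NNC(=O)COc1ccc(-c2nc3ccccc3s2)cc1OC`: 1980 nM
Compound 2 `CCOC(=O)[C@@H](NCC(=O)NNC(=O)COc1ccc(-c2nc3ccccc3s2)cc1OC)[C@@H](C)CC`: 1950 nM

Compound 2 stands at 1950 nM, within the scatter of compound 1 at 1980 nM. Compound 3 `CCOC(=O)[C@@H]1CCCN1CC(=O)NNC(=O)COc1ccc(-c2nc3ccccc3s2)cc1OC` carries 2-(ethoxycarbonyl)pyrrolidin-1-yl in place of (1-(ethoxycarbonyl)-2-methylbutyl)amino on a saturated chain carbon bound to a carbonyl carbon. One measured exchange at this place bears on the change: the step of a 1.0-fold lower number from compound 1 to compound 2 (0.01 log units; within the scatter), which lies within the scatter. No step beyond the scatter is therefore expected in this assay. The estimated step is a 1.0-fold higher number from compound 2 to compound 3 (0.01 log units; within the scatter). Compound 3 is expected at 2000 nM, with an estimated range of 800 nM to 5000 nM.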

Compound 3, half-maximal inhibitory concentration: 770 nM
Compound 3: middle estimate off by 2.6-fold (0.41 log units), on the high side; the whole stated range lies above it.
By their numbers in this assay, from the lowest: compound 3; then compounds 2 and 1 (each within the scatter of the next).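

In this assay, this place on a saturated chain carbon bound to a carbonyl carbon proves responsive to the exchange, which compounds 1 and 2 alone had not shown: the data give a 2.5-fold lower number from compound 2 to compound 3 (0.40 log units; beyond the scatter) and a 2.6-fold lower number from compound 1 to compound 3 (0.41 log units; beyond the scatter) as steps beyond the scatter. Of the three groups, only 2-(ethoxycarbonyl)pyrrolidin-1-yl holds a ring. No measurement shown accounts for this difference.

The compounds shown leave open whether a six-membered piperidine ring would read like the pyrrolidine. They also leave open how a free carboxylic acid in place of the ethyl ester would read.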